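Trading benzyl for isopropyl on a shared core

The source may report more compounds than this note shows. Statements on the series, on what has been measured and on what is new or still open speak of the compounds shown alone.

Compound 1 `Cc1ccc(S(=O)(=O)N(C)C(=O)NC(C)c2cc(Br)ccc2OC(C)C)cc1`: 34700 nM
Compound 2 `CC(C)Oc1ccc(Br)cc1C(C)NC(=O)NS(=O)(=O)c1ccccc1`: 143000 nM
Compound 3 `Cc1ccc(S(=O)(=O)NC(=O)NC(C)c2cc(Br)ccc2OCc2ccccc2)cc1`: 138000 nM

All three were tested in a functional assay on thoracic aorta (Rattus norvegicus, strain Wistar), with a stated time of 15 min; a higher number here means that more compound is needed for the effect, a lower number that less compound is needed. Compound 3 gives 138000 nM, the second highest of the three numbers; it sits within the scatter of compound 2, which gives 143000 nM, and well beyond the scatter above compound 1, which gives 34700 nM. Compound 4 `Cc1ccc(S(=O)(=O)NC(=O)NC(C)c2cc(Br)ccc2OC(C)C)cc1` differs from compound 3 by isopropyl in place of benzyl on an oxygen on an aromatic ring. For the measured compounds named here, no measured pair isolates this change, so its effect is uncertain. A step toward a lower number, of moderate size, is expected in a 2.3-fold lower number from compound 3 to compound 4 (0.36 log units; beyond the scatter), because compound 1, which also carries isopropyl on that oxygen, gives 34700 nM. Compound 4 is estimated at 60000 nM, with a range from 20000 nM to 180000 nM.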

Compound 4, half-maximal effective concentration: 61800 nM
Compound 4: the middle estimate sits 1.0-fold (0.01 log units) below what was measured; low and high end bracket the measured number.
By their numbers in this assay, from the lowest: compounds 1 and 4 (each within the scatter of the next); then compounds 3 and 2 (each within the scatter of the next).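

Replacing benzyl with isopropyl on the oxygen on the aromatic ring now has a measured effect on its own (a 2.2-fold lower number from compound 3 to compound 4 (0.35 log units; beyond the scatter)). Two other single changes can also be read: methyl in place of hydrogen on an aromatic carbon (a 2.3-fold lower number from compound 2 to compound 4 (0.36 log units; beyond the scatter)) and hydrogen in place of methyl on an amide-type nitrogen, which stays small (a 1.8-fold higher number from compound 1 to compound 4 (0.25 log units; within the scatter)). Nothing shown explains these steps.

Only benzyl and isopropyl are compared on that oxygen. As far as these compounds go, how an ethyl group, a longer chain or a chain ending in an amine would behave there remains open.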